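Aryl ketone variation in a stilbene chalcone series

The source may hold more compounds than are shown below. What is called first, only, known or untested is meant among the compounds shown, and "the series" means these compounds.

Working notes on compound 1 `CCCCOc1ccc(C(=O)/C=C/c2c(/C=C/c3ccc(OC)cc3)cc(OC)cc2OC)cc1`. In a functional assay on B16-F10 cells (Mus musculus) for antiproliferative activity, read by MTT assay, with a stated time of 48 h (on this read-out higher numbers stand for weaker inhibition and lower numbers for stronger inhibition), compound 1 gives 5.3 ug/mL, the lowest of the two numbers in hand. Among the compounds with values here, the only neighbour is compound 2 `COc1ccc(/C=C/c2cc(OC)cc(OC)c2/C=C/C(=O)c2ccccc2C)cc1`, which in this assay gives 6.1 ug/mL; the step of a 1.2-fold higher number from compound 1 to compound 2 (0.06 log units; within the scatter) exchanges the aryl group on the carbonyl carbon and stays within the scatter, so nothing separates these two.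

Compound 3 `COc1ccc(/C=C/c2cc(OC)cc(OC)c2/C=C/C(=O)c2ccc(-c3ccccc3)cc2)cc1` is not yet measured. It differs from compound 1 by phenyl in place of butoxy on an aromatic carbon. Within the data shown here, the one measured step that bears on it is the exchange of the aryl group on the carbonyl carbon, which gave a 1.2-fold higher number from compound 1 to compound 2 (0.06 log units; within the scatter); that the number hardly moved on that exchange is the only guide available. Nothing in hand suggests the phenyl will carry the number beyond the scatter, so compound 3 is expected to give 6 ug/mL, between 3 ug/mL and 12 ug/mL. The implied step a 1.1-fold higher number from compound 1 to compound 3 (0.05 log units; within the scatter) is expected to remain within the scatter.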

Compound 3, half-maximal inhibitory concentration: 10.6 ug/mL
Compound 3: the middle estimate sits 1.8-fold (0.25 log units) below what was measured; measured number inside the range.
By their numbers in this assay, from the lowest: compounds 1, 2 and 3 (each within the scatter of the next).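

Phenyl in place of butoxy, para to a large group, is the first change at this place to replace the chain with a ring, and in this assay it gives a 2.0-fold higher number from compound 1 to compound 3 (0.30 log units; within the scatter). Exchanging 2-methylphenyl for 4-phenylphenyl on the carbonyl carbon gives a 1.7-fold higher number from compound 2 to compound 3 (0.24 log units; within the scatter), so all three aryl ketones remain unseparated on this read-out, even with an added aromatic ring. No evidence on any property of these groups is available to interpret these steps.

Going by these compounds, whether an amine, a carboxylic acid or a chain longer than butoxy on this aryl group would carry the number beyond the scatter remains open. Also open, on these data alone, is whether changes elsewhere on the shared core would have any larger consequence in this assay.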